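A Methoxy Added to Compound 2

The source may report more compounds than this note shows. Statements on the series, on what has been measured and on what is new or still open speak of the compounds shown alone.

In an ADME assay on CCRF-CEM cells (Homo sapiens) for antiproliferative activity, with a stated time of 48 h (on this read-out higher numbers stand for weaker inhibition and lower numbers for stronger inhibition), compound 1 `C=C(Br)C(=O)Nc1ccc(C(=O)/C=C/c2cccc(OC)c2)cc1` gives 1800 nM, while compound 2 `COc1cccc(/C=C/C(=O)c2ccc(N)cc2)c1` gives 23000 nM, the higher of the two numbers. Within the data shown here, the only measured step, a 13-fold higher number from compound 1 to compound 2 (1.11 log units; beyond the scatter), concerns the group on the nitrogen, a different place from the one changing now. Compound 3 `COc1cccc(/C=C/C(=O)c2ccc(N)cc2)c1OC` carries methoxy in place of hydrogen on an aromatic carbon, ortho to a methoxy group: methoxy in place of hydrogen on an aromatic carbon. Among the measured compounds shown here, no measured step tests this change, so the expectation stays close to compound 2 at 23000 nM. The expected step, a 1.3-fold lower number from compound 2 to compound 3 (0.11 log units; within the scatter), is none beyond the scatter. Compound 3 is estimated at 18000 nM, with an expected range of 6000 nM to 50000 nM.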

Compound 3, half-maximal inhibitory concentration: 7600 nM
Compound 3: middle estimate off by 2.4-fold (0.37 log units), on the high side; measured number inside the range.
By their numbers in this assay, from the lowest: compound 1; then compound 3; then compound 2.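

In this assay, adding methoxy on an aromatic carbon, ortho to a methoxy group, gives a 3.0-fold lower number from compound 2 to compound 3 (0.48 log units; beyond the scatter) and so moves the number beyond the scatter. The earlier step concerned only the group on the nitrogen, so this shows that the read-out also responds to a change on this other ring position. Nothing measured here bears on the reason for this step.

From the compounds shown here alone, whether a hydroxyl or a fluorine at this position would do the same stays open. So does whether this added methoxy would lower the number of compound 1 as well.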